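A Carbonyl Arm in Place of a Vinyl Group

The compounds below may be only part of what the source reports. "The series", "measured", "known", "first", "only" and "open" are said of these compounds alone.

Of the compounds shown here, three have been tested in a functional assay on HepG2 cells (Homo sapiens) for cytotoxicity, read by MTT assay, with a stated time of 48 h; a higher number here means a weaker inhibitor, a lower number a stronger inhibitor. Compound 1 `CCOC(=O)CSc1nnc(C)n1N1C(=O)c2ccccc2C1=O` gives > 200000 nM, which is a limit of the assay rather than a number. Compound 2 `C#CCSc1nnc(CCC)n1N1C(=O)c2ccccc2C1=O` likewise gives > 200000 nM, again a limit. Compound 3 `C=CCSc1nnc(-c2cc(OC)c(OC)c(OC)c2)n1N1C(=O)c2ccccc2C1=O` gives > 200000 nM, also a limit. Within the data shown here, compound 3 therefore stands at the limit of > 200000 nM in this assay, at which 3 of the 3 values shown sit, and no step between measured compounds can be drawn, since every value shown is a limit. Compound 4 `COc1cc(-c2nnc(SCC(=O)c3ccc(F)cc3)n2N2C(=O)c3ccccc3C2=O)cc(OC)c1OC` has not yet been measured in this assay. It differs from compound 3 in one place: (4-fluorophenyl)carbonyl in place of vinyl on a saturated chain carbon bound to a sulfur. Allylsulfanyl thus becomes (((4-fluorophenyl)carbonyl)methyl)sulfanyl. Among the measured compounds shown here, with no measured step to lean on, the account can only note that compound 1, compound 2 and compound 3, though they differ in their groups, all sit at the same limit. The expected step of a number no higher from compound 3 to compound 4 (the limit leaves the size open) is accordingly none beyond the scatter. Compound 4 is expected to give about 200000 nM, between 60000 nM and 500000 nM, most likely once more as a limit.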

Compound 4, half-maximal inhibitory concentration: > 200000 nM
Compound 4: only a limit was reported (the forecaster's own chance of this, stated with the estimate: 70%); the middle value sits exactly at the limit.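

Among these compounds, compound 3 and compound 4 are both reported in this assay only as limits, so no step between them can be read: the limit of > 200000 nM in this assay, at which 4 of the 4 values shown sit. The compounds shown leave open whether any group on the shared core can yield a readable number at all.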